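Demethylation of an ether side chain on an A3 coumarin-type series

The compounds below may be only part of what the source reports. "The series", "measured", "known", "first", "only" and "open" are said of these compounds alone.

Measured compounds:
compound 1 `COCCNC(=O)c1cc2cccc(OC)c2oc1=N` gives 15%
compound 2 `N=c1oc2ccc(Br)cc2cc1C(=O)NCC(O)CO` gives 10%
compound 3 `COc1cccc2cc(C(=O)NCC(=O)O)c(=O)oc12` gives 15%

All three were tested in an assay on HeLa cells for displacement of a labelled ligand from adenosine receptor A3 (Homo sapiens), read by scintillation counting, with a stated time of 180 min, tested at 10 uM; a higher number here means more inhibition at the concentration tested (going by the name of the read-out), a lower number less inhibition. Compound 1 stands level with compound 3 at the digits recorded, and together they show the highest of the three numbers; compound 2 sits lower by an amount that does not exceed the usual scatter, so no ordering among the three can be asserted. Compound 4 `COc1cccc2cc(C(=O)NCCO)c(=N)oc12` has not yet been measured in this assay. It differs from compound 1 in a single place: hydrogen in place of methyl on an oxygen on a saturated carbon. Among the measured compounds shown here, no step between two measured compounds that differ in only one place is available, so there is nothing in the present set from which the size of this particular change can be read. Given that all three measured numbers lie within the scatter of one another and that compound 1 gives 15%, the step of a number 3 percentage points lower from compound 1 to compound 4 (within the scatter) is expected to be none beyond the scatter. Compound 4 is estimated to give 12%, with a range from 0% to 28%.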

Compound 4, a percentage reported as inhibition, at one concentration (the size of the read-out at that concentration, not a potency): 23%
For compound 4 the middle estimate is 11 percentage points below the measured one; the range from low to high includes it.
By their numbers in this assay, from the lowest: compounds 2, 1, 3 and 4 (each within the scatter of the next, the first and the last beyond it).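

The set now holds its first step that reads a single change: going from 2-methoxyethyl to 2-hydroxyethyl, this assay shows a number 8 percentage points higher from compound 1 to compound 4 (within the scatter). The methyl on this oxygen can therefore give way to hydrogen without a difference that stands out from the scatter, and the pair cannot be ranked. Nothing on hand offers a cause for this step.

A single step within the scatter leaves open whether this position responds to change at all, for instance with an amine or a carboxylic acid in place of the hydroxy group, or with a longer chain. Steps from compound 4 to compound 2 or compound 3 cannot be read, since those compounds differ from it in more than one place.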